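The source may hold more compounds than are shown below. What is called first, only, known or untested is meant among the compounds shown, and "the series" means these compounds.

Measured so far:
compound 1 `COc1ccc(-c2nn(-c3ccc(Cl)cc3)cc2-c2cc(-c3ccc(Cl)cc3)[nH]c2-c2ccc(OC)cc2)cc1`: 20.7%
compound 2 `COc1ccc(-c2nn(-c3ccc(S(N)(=O)=O)cc3)cc2-c2cc(-c3ccc(Cl)cc3)[nH]c2-c2ccc(F)cc2)cc1`: 55.9%

In a functional assay on the whole organism (strain Wistar albino) for inhibition, with Rattus norvegicus as the target, read by paw edema, with stated times of 1 h and 3 h, at a dose of 0.32 mmol/kg by the intraperitoneal route (a higher number here means more inhibition at the dose given (going by the name of the read-out), a lower number less inhibition), compound 2 gives 55.9%, the higher of the two numbers, while compound 1 gives 20.7%, a figure that sits below it by more than the usual scatter. Compound 3 `COc1ccc(-c2nn(-c3ccc(S(N)(=O)=O)cc3)cc2-c2cc(-c3ccc(Cl)cc3)[nH]c2-c2ccc(OC)cc2)cc1` has not been measured. It differs from compound 2 in one place: methoxy in place of fluoro on an aromatic carbon, the same difference read one bond further out being a 4-fluorophenyl becoming a 4-methoxyphenyl. Within the data shown here, no measured pair isolates this change, so in this assay only a small step is expected, downward if any. The estimate for compound 3 is 50%, within 35% to 65%, an expected step of a number 5.9 percentage points lower from compound 2 to compound 3 (within the scatter).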

Compound 3, a percentage reported as inhibition, in the whole organism at one dose (the size of the read-out at that dose, not a potency): 28.6%
Compound 3: the middle estimate sits 21.4 percentage points above what was measured, and the stated range ends above it.
By their numbers in this assay, from the lowest: compounds 1 and 3 (each within the scatter of the next); then compound 2.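

In this assay, methoxy in place of fluoro on this aromatic carbon is not a neutral swap: the 4-fluorophenyl to 4-methoxyphenyl change gives a number 27.3 percentage points lower from compound 2 to compound 3 (beyond the scatter). With the 4-methoxyphenyl kept, sulfamoyl in place of chloro gives a number 7.9 percentage points higher from compound 1 to compound 3 (within the scatter), so that change does not separate the two compounds. Nothing available explains the loss seen with methoxy. Open, as far as these compounds go, is how a methyl or a hydroxyl on this same carbon would compare with fluoro and methoxy. Also open, from the compounds shown here alone, is whether fluoro would give the same result with chloro in place of sulfamoyl.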